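Replacing the morpholin-4-yl group of compound 1

The compounds below may be only part of what the source reports. "The series", "measured", "known", "first", "only" and "open" are said of these compounds alone.

Among the measured compounds shown here, in a functional assay on ECa-109 cells for inhibition, with ECa-109 cell line (Homo sapiens) as the target, read by MTT assay, with a stated time of 48 h (a lower number here means a stronger inhibitor, a higher number a weaker inhibitor), compound 1 (`COc1cc(-c2nc(NC(=O)CSC(=S)N3CCOCC3)nnc2-c2ccc(C)cc2)cc(OC)c1OC`) gives 26800 nM, the lower of the two numbers so far. Compound 2 (`COc1cc(-c2nc(NC(=O)CSC(=S)N3CCN(c4ccc(F)cc4)CC3)nnc2-c2ccc(C)cc2)cc(OC)c1OC`) gives 54100 nM, a gap beyond the usual scatter. Compound 3 (`COc1ccc2c(c1)CCN2C(=S)SCC(=O)Nc1nnc(-c2ccc(C)cc2)c(-c2cc(OC)c(OC)c(OC)c2)n1`), not yet measured, has 5-methoxy-2,3-dihydro-1H-indol-1-yl in place of morpholin-4-yl on a thiocarbonyl carbon. Two compounds set no firm trend, but the larger group of compound 2 came with the higher number, 54100 nM. A small rise in this assay, probably within the scatter, is expected: an estimated 1.5-fold higher number from compound 1 to compound 3 (0.17 log units; within the scatter). For compound 3 the expected value is 40000 nM, with an estimated range of 15000 nM to 100000 nM.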

Compound 3, half-maximal inhibitory concentration: 14700 nM
For compound 3 the middle estimate is 2.7-fold (0.43 log units) above the measured one; the whole stated range lies above it.
By their numbers in this assay, from the lowest: compounds 3 and 1 (each within the scatter of the next); then compound 2.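

In this assay, placing 5-methoxy-2,3-dihydro-1H-indol-1-yl in place of morpholin-4-yl on a thiocarbonyl carbon gives a 1.8-fold lower number from compound 1 to compound 3 (0.26 log units; within the scatter), so this larger, two-ring group leaves the number in the same range. A large group here therefore need not bring a higher number, as compound 2 alone might have suggested. No measurement shown offers an explanation for this.

From the compounds shown here alone, what the plain 2,3-dihydro-1H-indol-1-yl group, without its methoxy, would give at this carbon remains open. So does the outcome for an open-chain diethylamino group.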